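The compounds below may be only part of what the source reports. "The series", "measured", "known", "first", "only" and "open" are said of these compounds alone.

Measured so far in an assay on isolated protein for inhibition of ATP-dependent RNA helicase DDX3X (Homo sapiens), read by FRET, with stated times of 30 s and 40 min; a lower number here means a stronger inhibitor, a higher number a weaker inhibitor:

compound 1 `CCCCc1cn(-c2ccc(NC(=O)Nc3cc(OC4CCCC4)ccc3C)cc2)nn1`: 140 nM
compound 2 `CCCCc1cn(-c2ccc(NC(=O)Nc3cc(O)ccc3C)cc2)nn1`: 490 nM
compound 3 `Cc1ccccc1NC(=O)Nc1ccc(-n2cc(CCCN3CCN(C)CC3)nn2)cc1`: 40100 nM

Compound 2 gives the second highest of the three numbers. Within the data shown here, its nearest neighbour is compound 1, reached by the single change of hydrogen in place of cyclopentyl on an oxygen on an aromatic ring, which is a 3.5-fold higher number from compound 1 to compound 2 (0.54 log units; beyond the scatter). Among the measured compounds shown here, compound 3 lies much further away, and as no single-point step connects it to compound 2, the two values show only that compound 3 is the weakest of the three.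

Compound 4 `CCCCc1cn(-c2ccc(NC(=O)Nc3cc(OCOC)ccc3C)cc2)nn1` differs from compound 2 in one place: methoxymethyl in place of hydrogen on an oxygen on an aromatic ring. For the measured compounds named here, the only measured step that bears on this position is the one from compound 1 to compound 2, where removing the cyclopentyl from that oxygen raised the number modestly. Going by the values given here, compound 4 puts a smaller non-ring group back onto the same oxygen, so a partial return toward compound 1 is the natural expectation, but no measured compound carries a methoxymethyl there, and the size of the effect is uncertain.

On that basis compound 4 is expected to come in around 250 nM, with a likely range of 100 nM to 700 nM, which means an estimated step of a 2.0-fold lower number from compound 2 to compound 4 (0.29 log units; within the scatter).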

Compound 4, half-maximal inhibitory concentration: 820 nM
Compound 4: the middle estimate sits 3.3-fold (0.52 log units) below what was measured; the measured number lies above the stated range.
By their numbers in this assay, from the lowest: compound 1; then compounds 2 and 4 (each within the scatter of the next); then compound 3.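

In this assay, methoxymethyl on the oxygen on the aromatic ring cannot be told apart from hydrogen at that place (a 1.7-fold higher number from compound 2 to compound 4 (0.22 log units; within the scatter)), so this change gives no measurable step in either direction. Cyclopentyl and methoxymethyl do separate (a 5.9-fold higher number from compound 1 to compound 4 (0.77 log units; beyond the scatter)), which shows that putting just any group back on this oxygen does not recover the number of compound 1; among the three groups seen here, only cyclopentyl stands apart, and the identity of the group matters at this position. No supporting measurement bears on what lies behind the gap between these two groups.

Open, from the compounds shown here alone, is whether the ring of the cyclopentyl is what counts, or whether an open chain could match it: a longer alkyl chain such as n-pentyl, a smaller ring such as cyclopropyl, or a plain methoxy on the same oxygen would help to settle this. Also open, going by these compounds, is how a terminal amine or a carboxylic acid on a chain at this oxygen would read, as would any such group with the butyl of the shared core replaced.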